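Ethoxy for methyl on a carbonyl carbon: compound 4

This account rests on a few compounds, and the source may have more. Where it says the series, first, only, none or still open, it means among the compounds named here.

In an ADME assay on MRC5 cells (Homo sapiens) for cytotoxicity, read by MTT assay, with a stated time of 96 h (a lower number here means that less compound is needed, a higher number that more compound is needed for the effect), compound 1 `COc1ccc(-c2[nH]c3ccc(OC)cc3c2/C=C(\C#N)S(=O)(=O)c2ccccc2)cc1` gives 22000 nM and compound 3 `COc1ccc2[nH]c(-c3ccccc3)c(/C=C(\C#N)S(=O)(=O)c3ccccc3)c2c1` gives 14000 nM. Within the data shown here, the only single-point step measured, a 1.6-fold lower number from compound 1 to compound 3 (0.20 log units; within the scatter), exchanges methoxy for hydrogen on an aromatic carbon and does not leave the scatter. Compound 2 `CC(=O)/C(=C/c1c(-c2ccccc2)[nH]c2ccccc12)C(=O)c1ccccc1` stands apart from both: in this assay compound 2 shows only a limit, > 100000 nM (the limit of > 100000 nM in this assay, at which 1 of the 3 values shown sits). Compound 4 `CCOC(=O)/C(=C/c1c(-c2ccccc2)[nH]c2ccccc12)C(=O)c1ccccc1` differs from compound 2 by ethoxy in place of methyl on a carbonyl carbon. No measured step touches a carbonyl carbon or this part of the shared core, so nothing shown supports a shift in either direction. Compound 4 is therefore expected near 100000 nM, between 40000 nM and 300000 nM, most likely returned again as a limit. The implied step, a number no higher from compound 2 to compound 4 (the limit leaves the size open), is expected to stay within the scatter.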

Compound 4, half-maximal effective concentration: > 100000 nM
Compound 4: no number, only a limit; the forecaster's own chance of this, stated with the estimate: 70%; the middle value lies on the limit itself.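

In this assay, among these compounds, compound 2 and compound 4 each return only a limit, so no step between them can be read. The compounds shown leave open what ethoxy in place of methyl on a carbonyl carbon does to the number.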